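Chloro in place of fluoro on compound 2

The source may hold more compounds than are shown below. What is called first, only, known or untested is meant among the compounds shown, and "the series" means these compounds.

Of the compounds shown here, two have numbers so far. In a functional assay on T29Kt1 cells (Homo sapiens) for cytotoxicity, read by sulforhodamine B assay, with a stated time of 3 days (a higher number here means a weaker inhibitor, a lower number a stronger inhibitor), compound 1 `O=Cc1cn(Cc2ccc(Cl)cc2)c2ccc(Cl)cc12` gives 10000 nM, and compound 2 `OCc1cn(Cc2ccc(Cl)cc2)c2ccc(F)cc12` gives 80 nM. Compound 2 holds the lower of the two numbers, and the gap lies beyond the usual scatter. Going by the values given here, these two compounds differ in more than one place, so the gap cannot be assigned to any single change, and no measured step speaks directly to a swap of halogens.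

The next compound is compound 3 `OCc1cn(Cc2ccc(Cl)cc2)c2ccc(Cl)cc12`, which departs from compound 2 in one substituent: chloro in place of fluoro on an aromatic carbon. In words, this is chloro in place of fluoro on an aromatic carbon. Among the compounds with values here, with no measured step to guide the call, the working expectation in this assay is no step beyond the scatter, with no firm direction. The expected change is a 1.3-fold lower number from compound 2 to compound 3 (0.12 log units; within the scatter), which is an estimate only. The anchor for this expectation is compound 2 at 80 nM, and the range is kept wide to reflect the thin data. For compound 3 the estimated value is 60 nM, with an expected range of 15 nM to 300 nM.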

Compound 3, half-maximal inhibitory concentration: 13000 nM
The estimate for compound 3 lay 220-fold (2.34 log units) below the measured number; the measured number lies above the stated range.
By their numbers in this assay, from the lowest: compound 2; then compounds 1 and 3 (each within the scatter of the next).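

In this assay this position on the shared core proves highly sensitive to the identity of the halogen: chloro in place of fluoro on an aromatic carbon gives a 160-fold higher number from compound 2 to compound 3 (2.21 log units; beyond the scatter) and is a large step for the exchange of a single heavy atom. With chloro at that position, hydroxymethyl in place of formyl gives a 1.3-fold higher number from compound 1 to compound 3 (0.11 log units; within the scatter) and stays within the scatter, so these two groups cannot be told apart in this setting, and among the one-place steps shown only the halogen exchange moves the number beyond the scatter. Nothing at hand accounts for the size of the halogen step or for the absence of a step between formyl and hydroxymethyl.

The compounds shown leave open how hydrogen, bromo, methoxy or nitrile at this position would read, and so whether fluoro is singular or one point in a broader trend. They also leave open whether formyl, a carboxylic acid or an amine in place of hydroxymethyl would still read alike with fluoro on the ring, or whether the group at that site matters only there.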